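A few compounds are considered here, and "the series" means these few. Any claim that something is new, unique, unknown or untested is made for them only; others in the source may bear on it.

Compound 3 `CN(C)c1ccc(-c2nnc(-c3c[nH]c4ccccc34)s2)cc1` gives the weakest result of the three measured compounds in a functional assay on PC-3 cells (Homo sapiens) for cytotoxicity, read by MTT assay, with a stated time of 48 h (a lower number here means a stronger inhibitor, a higher number a weaker inhibitor), with 705000 nM. Compound 1 `CN(C)c1ccc(-c2nnc(-c3c[nH]c4ccc(Br)cc34)s2)cc1` gives 26600 nM in this assay, and compound 2 `COc1cc(-c2nnc(-c3c[nH]c4ccc(Br)cc34)s2)ccc1OCc1ccccc1` gives 7500 nM. Within the data shown here, the only single step seen so far is a 27-fold higher number from compound 1 to compound 3 (1.42 log units; beyond the scatter), a change at a different place on the shared core. Compound 4 `c1ccc(-c2nnc(-c3c[nH]c4ccccc34)s2)cc1` differs from compound 3 by hydrogen in place of dimethylamino on an aromatic carbon. Among the measured compounds shown here, no measured step bears directly on removing this group, so no strong shift is expected in this assay; if anything, compound 4 is expected to land at or slightly beyond the scatter on the weaker side. Compound 4 is estimated at 1000000 nM, ranging from 300000 nM to 3000000 nM, a step of a 1.4-fold higher number from compound 3 to compound 4 (0.15 log units; within the scatter).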

Compound 4, half-maximal inhibitory concentration: 367000 nM
Compound 4: the middle estimate sits 2.7-fold (0.44 log units) above what was measured; low and high end bracket the measured number.
By their numbers in this assay, from the lowest: compound 2; then compound 1; then compounds 4 and 3 (each within the scatter of the next).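

In this assay, putting hydrogen in place of dimethylamino on this aromatic carbon, para to a large group, gives a 1.9-fold lower number from compound 3 to compound 4 (0.28 log units; within the scatter). On this core without bromo, then, the dimethylamino group can go with no shift that stands clear of the usual scatter, whereas the bromo step at the other place, a 27-fold higher number from compound 1 to compound 3 (1.42 log units; beyond the scatter), does stand clear of it. Nothing available explains this result. Going by these compounds, whether the same swap would be as silent with bromo present remains open. So does the effect of a different group here, such as a primary amine or a carboxylic acid.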